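Removing the amino group from a chloropurine core

This account rests on a few compounds, and the source may have more. Where it says the series, first, only, none or still open, it means among the compounds named here.

Compound 1 `Nc1nc(Cl)c2ncn(Cc3ccccc3CCl)c2n1` carries a chlorine, an amino group and a benzyl arm bearing a chloromethyl group on a fused two-ring core. In a functional assay on UACC-62 cells (Homo sapiens) for cytotoxicity, read by sulforhodamine B assay, with a stated time of 48 h (a higher number here means that more compound is tolerated, a lower number that less compound is tolerated), compound 1 gives 8510 nM, the highest of the two numbers recorded so far. Compound 2 `ClCc1ccccc1Cn1cnc2nc(Cl)nc(Cl)c21` differs at more than one point and gives 6760 nM in this assay, a result that lies within the usual scatter of compound 1, so no order between them can be read. Compound 3 `ClCc1ccccc1Cn1cnc2c(Cl)ncnc21` has not been measured; its change from compound 1 is hydrogen in place of amino on an aromatic carbon. For the measured compounds named here, with no measured pair that isolates this change, the step of a 1.2-fold lower number from compound 1 to compound 3 (0.08 log units; within the scatter) is expected to be small, toward slightly less tolerance at most, and may well stay within the scatter. Compound 3 is therefore estimated at 7000 nM, with a plausible range from 3000 nM to 18000 nM.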

Compound 3, concentration lethal to 50% of the cells: 28200 nM
Compound 3: middle estimate off by 4.0-fold (0.61 log units), on the low side; measured number above the stated range.
By their numbers in this assay, from the lowest: compounds 2 and 1 (each within the scatter of the next); then compound 3.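

Swapping the amino group for hydrogen on this aromatic carbon, between two ring nitrogen atoms, gives a 3.3-fold higher number from compound 1 to compound 3 (0.52 log units; beyond the scatter) in this assay, so more compound is tolerated without the amino group. The earlier pair could not show this, as compound 1 and compound 2 differ at more than one point and their numbers lie within the scatter of each other. No measurement shown here accounts for the rise.

Going by these compounds, whether any replacement of the amino group at this carbon would raise the number, or only hydrogen, remains open, as nothing shows a methyl group, a methoxy group or a dimethylamino group there. For the compounds shown here, also open is whether the same swap would give a similar step with a plain benzyl arm in place of the one bearing the chloromethyl group.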